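The source may hold more compounds than are shown below. What is called first, only, known or untested is meant among the compounds shown, and "the series" means these compounds.

Measured in a functional assay on SiHa cells (Homo sapiens) for inhibition, read by CCK-8 assay, with a stated time of 72 h, tested at 1 uM; a higher number here means more inhibition of growth at the concentration tested, a lower number less inhibition of growth:
Compound 1 `CN(C)C(=O)c1cc2cnc(Nc3ccc(NC(=O)C4(C(=O)Nc5cccc(Cl)c5)CC4)cc3)nc2n1C1CCCC1`: 16.2%
Compound 2 `CN(C)C(=O)c1cc2cnc(Nc3ccc(NC(=O)C4(C(=O)Nc5ccc(Cl)c(C(F)(F)F)c5)CC4)cc3)nc2n1C1CCCC1`: -11.2%

Compound 2 is the lower of the two. Compound 3 `CN(C)C(=O)c1cc2cnc(Nc3ccc(NC(=O)C4(C(=O)Nc5ccccc5)CC4)cc3)nc2n1C1CCCC1` differs from it as follows: phenyl in place of 4-chloro-3-(trifluoromethyl)phenyl on an amide-type nitrogen. This puts phenyl in place of 4-chloro-3-(trifluoromethyl)phenyl on an amide-type nitrogen. Going by the values given here, one measured step bears on this, a number 27.4 percentage points lower from compound 1 to compound 2 (beyond the scatter), which brought in the same group at that nitrogen and lies beyond the scatter. Among the compounds with values here, removing the group is therefore expected to give a rise of similar size in this assay, although no compound with plain phenyl has yet been measured. The expected change is a number 29.2 percentage points higher from compound 2 to compound 3 (beyond the scatter). Compound 3 is estimated at 18%, with an expected range of -5% to 42%.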

Compound 3, percent growth inhibition at one concentration: 58%
For compound 3 the middle estimate is 40 percentage points below the measured one; measured number above the stated range.
By their numbers in this assay, from the lowest: compound 2; then compound 1; then compound 3.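

In this assay, the group on this amide-type nitrogen matters more than the earlier pair showed: plain phenyl gives a number 69.2 percentage points higher from compound 2 to compound 3 (beyond the scatter), and removing only the chloro gives a number 41.8 percentage points higher from compound 1 to compound 3 (beyond the scatter). Even the single chloro of compound 1 therefore comes with a much lower number, and compound 3, with no substituent on this ring, stands highest of the three. Nothing available explains this difference. Still open, on these data alone, is whether a methoxy group or an amine on this ring would keep the number high, or would lower it as chloro does.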